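From compound 3 to compound 4: a methyl moved

This account rests on a few compounds, and the source may have more. Where it says the series, first, only, none or still open, it means among the compounds named here.

Compound 1 `CC(/C=N/Nc1ccc([N+](=O)[O-])cc1)=N\NC(=O)c1ccccc1Cl`: in an ADME assay on J774 cells (Mus musculus, strain BALB/c) for cytotoxicity, read by resazurin assay, with a stated time of 72 h (on this read-out higher numbers stand for lower toxicity in this test and lower numbers for higher toxicity in this test), compound 1 gives > 100000 nM, a limit of the assay.
Compound 2 `CC(/C=N/Nc1ccc([N+](=O)[O-])cc1)=N\NC(=O)c1ccc(O)cc1`: in this assay compound 2 gives 51000 nM.
Compound 3 `CC(/C=N/Nc1ccc([N+](=O)[O-])cc1)=N\NC(=O)c1ccccc1C`: in this assay compound 3 gives > 100000 nM, again a limit.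

Compound 3 therefore stands only at a limit, as does compound 1, which is the limit of > 100000 nM in this assay, at which 2 of the 3 values shown sit. Compound 4 `CC(/C=N/Nc1ccc([N+](=O)[O-])cc1)=N\NC(=O)c1cccc(C)c1` differs from compound 3 by 3-methylphenyl in place of 2-methylphenyl on a carbonyl carbon. For the measured compounds named here, no measured step moves a methyl from one position to another, so none bears directly on this change. The steps seen are an at least 1.9-fold lower number from compound 1 to compound 2 (0.29 log units; that floor lies within the scatter), an at least 1.9-fold higher number from compound 2 to compound 3 (0.29 log units; that floor lies within the scatter) and a step that the two limits leave unreadable from compound 1 to compound 3; none is readable beyond the scatter. No step beyond the scatter is expected in this assay. Compound 4 is estimated at 100000 nM, between 40000 nM and 250000 nM, most likely once more a limit, which would mean a number no higher from compound 3 to compound 4 (the limit leaves the size open).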

Compound 4, half-maximal cytotoxic concentration: > 100000 nM
Compound 4: only a limit was reported; the forecaster's own chance of this, stated with the estimate: 70%; the middle value lies on the limit itself.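

In this assay compound 4 gives > 100000 nM, a limit. The steps to compound 4 from compound 3 and from compound 1 cannot be read, so moving the methyl from 2-methylphenyl to 3-methylphenyl leaves no readable mark in this range: the limit of > 100000 nM in this assay, at which 3 of the 4 values shown sit. For the compounds shown here, the only step with a stated floor is an at least 1.9-fold higher number from compound 2 to compound 4 (0.29 log units; that floor lies within the scatter).

As far as these compounds go, whether the place of the methyl matters at all in this assay therefore stays open. So does how an amine or a carboxylic acid on this ring would read.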